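The compounds below may be only part of what the source reports. "The series", "measured", "known", "first", "only" and "open" are said of these compounds alone.

In a physicochemical assay for lipophilicity, in phosphate buffer, measured as octanol-water partition (a lower number here means a more polar compound, a higher number a more lipophilic compound), three compounds have been measured:

compound 1, `O=C(NC(=S)Nc1ccccc1)Nc1ccc2c(c1)C(=O)C(=O)N2Cc1ccccc1Cl` — 3.18
compound 2, `O=C(NC(=S)Nc1ccccc1Cl)Nc1ccc2c(c1)C(=O)C(=O)N2Cc1ccccc1Cl` — 3.98
compound 3, `Cc1cccc(NC(=S)NC(=O)Nc2ccc3c(c2)C(=O)C(=O)N3Cc2ccccc2Cl)c1` — 3.72

Compound 3 stands second highest of the three. Its nearest neighbour is compound 2, and the gap a number 0.26 log units lower from compound 2 to compound 3 (within the scatter) lies within the scatter, so no order between these two can be claimed. Against compound 1 the step of a number 0.54 log units higher from compound 1 to compound 3 (beyond the scatter) is beyond the scatter, and the step of a number 0.80 log units higher from compound 1 to compound 2 (beyond the scatter) is larger still.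

Compound 4, `COc1cccc(NC(=S)NC(=O)Nc2ccc3c(c2)C(=O)C(=O)N3Cc2ccccc2Cl)c1`, is the next compound, not yet measured. It differs from compound 3 in one place: methoxy in place of methyl on an aromatic carbon. Among the measured compounds shown here, of the measured steps, only the one from compound 1 to compound 3 bears on this change, since it shows what the methyl that now leaves had added, namely a number 0.54 log units higher from compound 1 to compound 3 (beyond the scatter). For the measured compounds named here, no measured pair shows what a methoxy adds in its place, so that part of the step rests on general experience with this kind of measurement rather than on these compounds. Taken together, a modest downward step a number 0.47 log units lower from compound 3 to compound 4 (beyond the scatter) is expected in this assay. Compound 4 is therefore estimated at 3.25, with a range from 2.85 to 3.65.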

Compound 4, partition coefficient: 3.19
Beside the measured number, compound 4's estimate is 0.06 log units above it, within the range that was stated.
By their numbers in this assay, from the lowest: compounds 1 and 4 (each within the scatter of the next); then compounds 3 and 2 (each within the scatter of the next).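

In this assay, among the compounds shown here, swapping the methyl for a methoxy gives a number 0.53 log units lower from compound 3 to compound 4 (beyond the scatter), which shows that this position does not treat the two groups alike, something the earlier compounds, none of which carried a methoxy, could not show. Methoxy in place of hydrogen gives a number 0.01 log units higher from compound 1 to compound 4 (within the scatter), so these two compounds cannot be told apart in this measurement, whereas methyl in place of hydrogen on the same ring gave a number 0.54 log units higher from compound 1 to compound 3 (beyond the scatter) in the same measurement. The 3-methoxyphenyl in place of the 2-chlorophenyl gives a number 0.79 log units lower from compound 2 to compound 4 (beyond the scatter), a step of much the same size as the one that chloro gave on the parent, a number 0.80 log units higher from compound 1 to compound 2 (beyond the scatter), so the two substituted rings now stand well apart, although each differs from compound 1 in one place only.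

Nothing available accounts for any of these steps.
Whether the match between methoxy and hydrogen holds for other groups at this place, such as an ethoxy, a hydroxyl or an amine, or for methoxy elsewhere on this ring, remains open in the compounds shown.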